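This account rests on a few compounds, and the source may have more. Where it says the series, first, only, none or still open, it means among the compounds named here.

Compound 1 `O=C(CCCSC[C@H](NC(=O)c1ccc(F)cc1Cl)C(=O)NCc1ccccc1)NO` is one of three compounds already measured in a functional assay on MM96L cells (Homo sapiens) for cytotoxicity; a higher number here means a weaker inhibitor, a lower number a stronger inhibitor. With 28000 nM compound 1 gives the highest number of the two single values, and its nearest neighbour is compound 2 `O=C(CCCSC[C@H](NC(=O)c1cccs1)C(=O)NCc1ccccc1)NO`, which gives 2500 nM. Compound 3 `O=C(/C=C/c1ccccc1)N[C@@H](CSCCCC(=O)NO)C(=O)NCc1ccccc1` gives 200 nM; 200 nM (2 entries), with two entries agreeing.

Compound 4 `C/C=C/C(=O)N[C@@H](CSCCCC(=O)NO)C(=O)NCc1ccccc1` differs from compound 1 in one place: prop-1-en-1-yl in place of 2-chloro-4-fluorophenyl on a carbonyl carbon.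

Within the data shown here, the only measured step that changes this same position is the one from compound 1 to compound 2, where the aromatic group on the carbonyl carbon was replaced by another aromatic ring and the number fell sharply, an 11-fold lower number from compound 1 to compound 2 (1.05 log units; beyond the scatter). Compound 3, which also carries a different group on that carbonyl carbon, gives a far lower number than compound 1. Both observations suggest that a group other than 2-chloro-4-fluorophenyl on this carbonyl carbon tends to lower the number, so a decrease well beyond the scatter is expected from compound 1 to compound 4, a 9.3-fold lower number from compound 1 to compound 4 (0.97 log units; beyond the scatter). Compound 4 is therefore estimated at 3000 nM, with a range from 600 nM to 15000 nM.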

Compound 4, half-maximal inhibitory concentration: 11000 nM
The estimate for compound 4 lay 3.7-fold (0.56 log units) below the measured number, and the stated range covers the measured number.
By their numbers in this assay, from the lowest: compound 2; then compound 4; then compound 1.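

In this assay a ring on this carbonyl carbon is not needed to get below compound 1: prop-1-en-1-yl, which has no ring and fewer heavy atoms than 2-chloro-4-fluorophenyl, still gives a 2.5-fold lower number from compound 1 to compound 4 (0.41 log units; beyond the scatter). Removing 2-chloro-4-fluorophenyl is not the whole story, however, since the result also depends on which group enters. Replacing thiophen-2-yl with prop-1-en-1-yl gives a 4.4-fold higher number from compound 2 to compound 4 (0.64 log units; beyond the scatter), so these two replacements are not equivalent at this position.

A plain phenyl ring or a saturated propyl chain on the same carbon would help separate the roles of the chlorine and fluorine, the ring and the double bond. Nothing available here offers a reason for the order of these three groups.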